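The source may report more compounds than this note shows. Statements on the series, on what has been measured and on what is new or still open speak of the compounds shown alone.

Two measured compounds open the set. Compound 1 `COc1cc(OC)c(OC)cc1/C=C/C(=O)c1ccc([N+](=O)[O-])cc1` gives 2.34 ug/mL in a functional assay on cells (Erythrocyte, Rattus norvegicus) for inhibition, read by hemolysis, with a stated time of 1 h; on this read-out lower numbers stand for stronger inhibition and higher numbers for weaker inhibition. Compound 2 `COc1cc(OC)c(-c2cc(=O)c3cc(Cl)ccc3o2)cc1OC` gives 2.13 ug/mL in this assay. Of these two numbers, compound 1 has the higher one, but the gap between compound 1 and compound 2 is within the usual scatter, so the two cannot be ranked against each other on this evidence; they simply behave alike.

The unmeasured compound 3 `COc1cc(OC)c(OC)cc1/C=C/C(=O)c1ccc(Br)cc1` is made from compound 1 by a single change: bromo in place of nitro on an aromatic carbon. Among the measured compounds shown here, no pair of measured compounds shows what this kind of change does in this assay, so there is no measured step to lean on. Both groups sit at the same place on the same ring, and the rest of the structure of compound 1 is kept, so no strong shift in either direction is expected; any movement from compound 1 to compound 3 would most likely stay inside the scatter, and the estimated step is a 1.2-fold higher number from compound 1 to compound 3 (0.08 log units; within the scatter). On that basis compound 3 is expected to give about 2.8 ug/mL in this assay, with a plausible range from 1.3 ug/mL to 6 ug/mL.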

Compound 3, half-maximal inhibitory concentration: 2.3 ug/mL
For compound 3 the middle estimate is 1.2-fold (0.09 log units) above the measured one; measured number inside the range.
By their numbers in this assay, from the lowest: compounds 2, 3 and 1 (each within the scatter of the next).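

In this assay, among the compounds shown here, putting bromo in place of nitro on this aromatic carbon gives a 1.0-fold lower number from compound 1 to compound 3 (0.01 log units; within the scatter), which is the first measured step in the set. On the core of compound 1, then, the read-out does not tell these two groups apart at this place, para to a large group, even though nitro has 3 heavy atoms and 2 hydrogen-bond acceptors while bromo has 1 heavy atom and no hydrogen-bond acceptors. Nothing measured here accounts for the two groups behaving alike.

This single pair leaves open whether the same aromatic carbon would tolerate any other kind of group, such as an amine, a carboxylic acid or a longer alkyl chain, or whether a clear change in hemolysis inhibition would appear with one of them. It also leaves open whether bromo and nitro would match in the same way on a different core, since one step on one core cannot show how general this result is.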